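A few compounds are considered here, and "the series" means these few. Any claim that something is new, unique, unknown or untested is made for them only; others in the source may bear on it.

Compound 3 `O=C(Nc1ccc(Cl)c(-c2nnc3c(Cl)cccn23)c1)c1ccc(Cl)cc1Cl` carries a 2,4-dichlorophenyl on the carbonyl carbon of its amide. Among the measured compounds shown here, in a functional assay on A549 cells (Homo sapiens) for antiproliferative activity, read by MTT assay, with a stated time of 72 h (a higher number here means a weaker inhibitor, a lower number a stronger inhibitor), compound 3 gives 61300 nM, the only outright number among the three measured compounds. Compound 1 `O=C(Nc1ccc(Cl)c(-c2nnc3c(Cl)cccn23)c1)c1ccc(F)cc1Cl` reaches only the limit of this assay, at > 100000 nM. Compound 2 `Cc1cc(Cl)ccc1C(=O)Nc1ccc(Cl)c(-c2nnc3c(Cl)cccn23)c1` likewise stops at the limit, at > 100000 nM. Both steps toward compound 3 therefore read only as floors: an at least 1.6-fold lower number from compound 1 to compound 3 (0.21 log units; that floor lies within the scatter) and an at least 1.6-fold lower number from compound 2 to compound 3 (0.21 log units; that floor lies within the scatter), in keeping with the limit of > 100000 nM in this assay, at which 2 of the 3 values shown sit. Compound 4 `O=C(Nc1ccc(Cl)c(-c2nnc3c(Cl)cccn23)c1)c1ccon1` changes the group on the carbonyl carbon far more deeply: 1,2-oxazol-3-yl in place of 2,4-dichlorophenyl on a carbonyl carbon. For the measured compounds named here, none of the measured steps tests such a swap; they exchange only halogens or a methyl on the phenyl that compound 4 loses. With the whole set sitting at or near the limit, compound 4 is expected to show no step beyond the scatter, a 1.6-fold higher number from compound 3 to compound 4 (0.21 log units; within the scatter). The estimate for compound 4 in this assay is 100000 nM, with a range from 30000 nM to 300000 nM, and a real chance that only the limit is reported.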

Compound 4, half-maximal inhibitory concentration: 42700 nM
Compound 4: middle estimate off by 2.3-fold (0.37 log units), on the high side, and the stated range covers the measured number.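

Putting 1,2-oxazol-3-yl on the carbonyl carbon shows that this place accepts a ring of a different size with hetero atoms in it, not only a change of substituents on a phenyl, and in this assay the exchange for 2,4-dichlorophenyl gives a 1.4-fold lower number from compound 3 to compound 4 (0.16 log units; within the scatter). Against the other two phenyl amides, the same kind of exchange gives an at least 2.3-fold lower number from compound 2 to compound 4 (0.36 log units; beyond the scatter) and an at least 2.3-fold lower number from compound 1 to compound 4 (0.36 log units; beyond the scatter), the first steps in this set that clearly clear the scatter. Both are only floors, since each starts from a limit rather than a number: the limit of > 100000 nM in this assay, at which 2 of the 4 values shown sit.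

Going by these compounds, whether an amine such as morpholine or a simple alkyl chain on the carbonyl carbon would hold this level or take the number well lower stays open. So does whether another five-membered ring, such as a thiophene, would behave like 1,2-oxazol-3-yl.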